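This account rests on a few compounds, and the source may have more. Where it says the series, first, only, none or still open, it means among the compounds named here.

The series shares one core; compound 1 `CC(C)CCn1ccc(-c2ccc(OCC3CC3)cc2)c(C#N)c1=O` carries a cyclopropylmethyl on the aromatic oxygen. In a functional assay on CHO cells for positive allosteric modulation of metabotropic glutamate receptor 2 (Homo sapiens), read by scintillation counting and GTPgammaS binding, with a stated time of 30 min (a higher number here means that more compound is needed for the effect, a lower number that less compound is needed), compound 1 gives 290 nM. Compound 2 `CC(C)CCn1ccc(-c2ccc(OCC3CC3)c(Cl)c2)c(C#N)c1=O` adds a chloro on an aromatic carbon, and in this assay compound 2 gives 110 nM, which is a 2.6-fold lower number from compound 1 to compound 2 (0.42 log units; beyond the scatter). Compound 3 `CC(C)CCn1ccc(-c2ccc(Oc3ccccc3)cc2)c(C#N)c1=O` puts phenyl on the oxygen in place of cyclopropylmethyl; in this assay compound 3 gives 42 nM, the lowest of the three numbers, reached as a 6.9-fold lower number from compound 1 to compound 3 (0.84 log units; beyond the scatter), with the gap to compound 2 also beyond the scatter. Compound 4 `CC(C)CCn1ccc(-c2ccc(Oc3ccncc3)cc2)c(C#N)c1=O` differs from compound 3 only in pyridin-4-yl in place of phenyl on an oxygen on an aromatic ring. Going by the values given here, no measured step exchanges one aromatic ring on that oxygen for another; the single change at that oxygen, a 6.9-fold lower number from compound 1 to compound 3 (0.84 log units; beyond the scatter), concerns an aliphatic group and does not transfer to this case. Among the compounds with values here, nothing among the measured steps therefore bears directly on the exchange, and no step beyond the scatter is expected: a 1.7-fold higher number from compound 3 to compound 4 (0.22 log units; within the scatter). Compound 4 is expected to give 70 nM in this assay, within 25 nM to 200 nM.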

Compound 4, half-maximal effective concentration: 550 nM
The estimate for compound 4 lay 7.9-fold (0.90 log units) below the measured number; the measured number lies above the stated range.
By their numbers in this assay, from the lowest: compound 3; then compound 2; then compounds 1 and 4 (each within the scatter of the next).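

At the oxygen on an aromatic ring, one ring nitrogen in place of a ring carbon, with the heavy-atom count unchanged, is not a neutral exchange: pyridin-4-yl in place of phenyl gives a 13-fold higher number from compound 3 to compound 4 (1.12 log units; beyond the scatter) in this assay, a large step. The gain seen with phenyl over cyclopropylmethyl therefore does not extend to every aromatic ring on this oxygen, since pyridin-4-yl in place of cyclopropylmethyl gives only a 1.9-fold higher number from compound 1 to compound 4 (0.28 log units; within the scatter). Nothing available explains the loss.

Open, as far as these compounds go, is whether pyridin-3-yl or pyridin-2-yl on the same oxygen follows phenyl or pyridin-4-yl, which would show whether the place of the ring nitrogen matters. Also open, from the compounds shown here alone, is whether a 4-fluorophenyl or 4-methoxyphenyl group keeps the value of compound 3, and whether the chloro of compound 2 adds to the phenyl change.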